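The source may report more compounds than this note shows. Statements on the series, on what has been measured and on what is new or still open speak of the compounds shown alone.

Measured in a functional assay on Huh-7 cells (Homo sapiens) for antiproliferative activity, read by sulforhodamine B assay, with a stated time of 72 h; a higher number here means a weaker inhibitor, a lower number a stronger inhibitor:
- Compound 1 `Nc1nc(N2CCN(c3ncccn3)CC2)c2ncn([C@@H]3O[C@H](CO)[C@@H](O)[C@H]3O)c2n1`: "not active" (no number reported)
- Compound 2 `Nc1nc(N2CCN(c3ccccc3)CC2)c2ncn([C@@H]3O[C@H](CO)[C@@H](O)[C@H]3O)c2n1`: 50000 nM

These two entries are all that is known so far in this assay. Among the compounds with values here, compound 2, at 50000 nM, holds the only number, while compound 1 is recorded as "not active" (no number reported), with no number attached. There is therefore no ranking to speak of, and compound 2 stands alone as the single numerical reference point.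

Compound 3 `Cc1ccc(N2CCN(c3nc(N)nc4c3ncn4[C@@H]3O[C@H](CO)[C@@H](O)[C@H]3O)CC2)cc1` departs from compound 2 in one place: methyl in place of hydrogen on an aromatic carbon. This is methyl in place of hydrogen on an aromatic carbon, para to a large group, and the rest of the molecule stays the same.

Within the data shown here, no pair of measured compounds shows what a single change does here, so any expectation is loosely grounded. A small step is expected in this assay, perhaps toward a slightly lower number and hardly beyond the scatter. The estimated move is a 1.6-fold lower number from compound 2 to compound 3 (0.19 log units; within the scatter). A result without a number, as for compound 1, also remains possible. For compound 3 the estimated value is 32000 nM, with an expected range from 11000 nM to 90000 nM.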

Compound 3, half-maximal inhibitory concentration: "not active" (no number reported)
For compound 3 the study gives words and no number; there is nothing to compare the estimate with.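

Compound 3, like compound 1, is recorded in this assay in words only, so no step can be read between it and compound 2, which gives 50000 nM. No available evidence bears on this result. The compounds shown leave open how far the change from phenyl to 4-methylphenyl moves the activity in this assay.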